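Kinetic solubility notes: oxazole amide series, compound 4

This account rests on a few compounds, and the source may have more. Where it says the series, first, only, none or still open, it means among the compounds named here.

Measured so far in a physicochemical assay for solubility, in phosphate buffer, measured as kinetic solubility, at pH 7.4; a lower number here means a less soluble compound, a higher number a more soluble compound:
- compound 1, `Cc1ccccc1-c1nc(CN2CCC(C(=O)N3CCN(C4CCN(C)CC4)CC3)CC2)c(C)o1`, gives > 71 ug/mL, a limit of the assay.
- compound 2, `Cc1oc(-c2c(Cl)cccc2C(F)(F)F)nc1CN1CCC(C(=O)NCCCN2C[C@H](C)C[C@H](C)C2)CC1`, gives 65.1 ug/mL.
- compound 3, `Cc1ccccc1-c1nc(CN2CCC(C(=O)N3CCN(CCN(C)C)CC3)CC2)c(C)o1`, gives > 67 ug/mL, a limit of the assay.

Among the measured compounds shown here, compound 2 stands as the only read number among the three values shown; the other two are limits. For the measured compounds named here, the single step between measured compounds that differ in one place, a step that the two limits leave unreadable from compound 1 to compound 3, cannot be sized because both ends are limits, the limit of > 67 ug/mL in this assay, at which 1 of the 3 values shown sits, and (the limit of > 71 ug/mL in this assay, at which 1 of the 3 values shown sits). That step concerns the amine end of the shared core and says nothing about the aryl group on the oxazole.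

Compound 4, `Cc1cc(C)cc(-c2nc(CN3CCC(C(=O)NCCCN4C[C@H](C)C[C@H](C)C4)CC3)c(C)o2)c1`, differs from compound 2 in one place: 3,5-dimethylphenyl in place of 2-chloro-6-(trifluoromethyl)phenyl on an aromatic carbon. Going by the values given here, no measured step bears on this change, so there is no measured size to carry over. With nothing pointing either way, the expected step is none beyond the scatter: a 1.1-fold higher number from compound 2 to compound 4 (0.03 log units; within the scatter) is the estimate. Compound 4 is therefore expected to give 70 ug/mL in this assay, with a range of 35 ug/mL to 140 ug/mL. Since both limits recorded sit close to the number of compound 2, a limit rather than a number is a real possibility for compound 4.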

Compound 4, solubility: > 71 ug/mL
Compound 4 gave a limit, no number (the forecaster's own chance of this, stated with the estimate: 45%); middle value at least 1.0-fold (0.00 log units) away from the limit.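

Among the compounds shown here, at the aromatic carbon of the five-membered aromatic ring with 1 nitrogen and 1 oxygen, the earlier compounds offered no measured step, and in this assay the exchange of 2-chloro-6-(trifluoromethyl)phenyl for 3,5-dimethylphenyl now gives one, readable only as a floor: an at least 1.0-fold higher number from compound 2 to compound 4 (0.03 log units; that floor lies within the scatter). Compound 4 gives > 71 ug/mL, which is a limit of the assay, so the step has a floor but no size, and this limit recurs in the series: the limit of > 71 ug/mL in this assay, at which 2 of the 4 values shown sit. For this one pair, a group of 11 heavy atoms including chlorine and fluorine gives way to an all-carbon group of 8 heavy atoms, and no loss appears in this assay, though a single pair sets no pattern for this position.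

From the compounds shown here alone, how far compound 4 lies past its limit stays open, and the step between compound 1 and compound 3 still cannot be read. Also open, going by these compounds, is whether the same floor would hold for a 3,5-dichlorophenyl group at this position, or for a morpholine or a carboxylic acid at the amine end of the shared core.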